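The compounds below may be only part of what the source reports. "The series", "measured", "known", "first", "only" and "open" are said of these compounds alone.

In an ADME assay on SK-MEL-2 cells (Homo sapiens) for cytotoxicity (a lower number here means that less compound is needed, a higher number that more compound is needed for the effect), the compounds are compared by how much of each is needed to harm the cells. Compound 1 `O=C1N[C@@H](c2c[nH]c3ccccc23)CN=C1c1c[nH]c2ccccc12` gives 5 ug/mL there. Compound 2 `O=C1NC[C@@H](c2c[nH]c3ccccc23)N[C@H]1c1c[nH]c2ccccc12` is a different case, because its result in this assay is > 10 ug/mL, which is a limit of the assay and not a number. Compound 3 `O=C(C1=NC(c2c[nH]c3cc(Br)ccc23)CN1)c1c[nH]c2ccccc12` gives 5.04 ug/mL in this assay. Within the data shown here, of the two numbers known, that of compound 3 is the higher one, yet its nearest neighbour is compound 1, and the gap between the two lies within the scatter of repeated measurements, so the two cannot be told apart. Among the measured compounds shown here, the one further value is the limit of compound 2, described by the limit of > 10 ug/mL in this assay, at which 1 of the 3 values shown sits.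

Compound 4 `O=C(C1=NC(c2c[nH]c3cc(Br)ccc23)CN1)c1c[nH]c2cc(Br)ccc12` is the next compound. It differs from compound 3 in one place: bromo in place of hydrogen on an aromatic carbon. For the measured compounds named here, compound 3 already carries one bromo group on its other aromatic ring, and no measured pair shows what a second one does. For this assay the expected step from compound 3 to compound 4 is therefore small, a 1.1-fold lower number from compound 3 to compound 4 (0.05 log units; within the scatter), with no clear direction beyond the scatter. Compound 4 is thus expected to give about 4.5 ug/mL, somewhere between 1.5 ug/mL and 10 ug/mL.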

Compound 4, concentration for half-maximal effect: 4.82 ug/mL
The estimate for compound 4 lay 1.1-fold (0.03 log units) below the measured number, within the range that was stated.
By their numbers in this assay, from the lowest: compounds 4, 1 and 3 (each within the scatter of the next). At a limit, above all of these: compound 2.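

In this assay, the change to bromo in place of hydrogen on an aromatic carbon gives a 1.0-fold lower number from compound 3 to compound 4 (0.02 log units; within the scatter), so the two compounds cannot be told apart in this assay. Among these compounds, this is the first pair in the set that differs in only one place, and so the first direct reading of a single change: at this carbon of a six-membered aromatic ring of carbon only, part of a fused system of two rings, meta to a fused ring and para to a fused ring, one added bromine atom produces no step that can be distinguished from the ordinary spread of repeated measurements. No measurement shown gives a reason for this outcome.

This single pair cannot say whether a different kind of group on the same carbon, such as an amine, a carboxylic acid or a longer chain, would also stay within the scatter or would move the number beyond it. Also open is what the bromo group already present on the other aromatic ring of compound 3 contributes, as no pair shown isolates that group.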